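The source may report more compounds than this note shows. Statements on the series, on what has been measured and on what is new or still open speak of the compounds shown alone.

Working notes on the series in an ADME assay for permeability, using PAMPA, at pH 7.4; on this read-out lower numbers stand for lower permeability and higher numbers for higher permeability. Of the compounds shown here, three have numbers so far. Compound 1 `COc1ccc2c(=O)cc(C)[nH]c2c1` reads 8.91 10^-6 cm/s. Compound 2 `Cc1[nH]c2ccccc2c(=O)c1Br` reads 13.6 10^-6 cm/s, which lies within the scatter of compound 1. Compound 3 `Cc1[nH]c2ccccc2c(=O)c1/C=C/c1ccccc1` reads 224 10^-6 cm/s, beyond the scatter of compound 2 and far from both others on the scale. For the measured compounds named here, compound 2 therefore sits with compound 1 at the low end of the numbers so far, with compound 3 well clear of the pair.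

Compound 4 `Cc1[nH]c2ccc(F)cc2c(=O)c1Br` has no number yet. It differs from compound 2 in one place: fluoro in place of hydrogen on an aromatic carbon. This is fluoro in place of hydrogen on an aromatic carbon. Going by the values given here, no pair of measured compounds differs in one place, so the data give no direct size for this change. The wide gap between compound 2 and compound 3 comes with a different substituent and cannot be carried over. The expectation therefore starts from compound 2 at 13.6 10^-6 cm/s and assumes no shift beyond the scatter, with no firm direction. The expected move, a 1.2-fold higher number from compound 2 to compound 4 (0.07 log units; within the scatter), is estimated to stay within the scatter in this assay. For compound 4 the estimated value is 16 10^-6 cm/s, with an expected range from 8 10^-6 cm/s to 32 10^-6 cm/s.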

Compound 4, apparent permeability: 18.3 10^-6 cm/s
Estimate against measurement, compound 4: 1.1-fold (0.06 log units) below; measured number inside the range.
By their numbers in this assay, from the lowest: compounds 1, 2 and 4 (each within the scatter of the next, the first and the last beyond it); then compound 3.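

In this assay, for the compounds shown here, fluoro in place of hydrogen on an aromatic carbon of the shared core, meta to a fused ring and para to a fused ring, gives the first single-place step (a 1.3-fold higher number from compound 2 to compound 4 (0.13 log units; within the scatter)). This gives the series its first direct reading for a change at this position, and in this one pair, with all else in compound 2 kept, the fluoro swap stays within the usual scatter of the read-out, so the position accepts this one atom without a separable shift in the number. No measurement at hand accounts for the size of this step.

One pair says nothing yet about other groups on the same aromatic carbon, such as chloro, trifluoromethyl, an amine or a carboxylic acid, any of which could give a step beyond the scatter or stay within it. As far as these compounds go, it is also open whether the same fluoro swap would stay within the scatter on the core of compound 3 (224 10^-6 cm/s), which stands well clear of the other compounds on the scale.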